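Replacing the 5-methylfuran-2-yl end of compound 2

The source may hold more compounds than are shown below. What is called first, only, known or untested is meant among the compounds shown, and "the series" means these compounds.

In a functional assay on MCF7 cells (Homo sapiens) for inhibition, read by MTT assay, with a stated time of 3 days (a higher number here means a weaker inhibitor, a lower number a stronger inhibitor), compound 1 `Cc1cc(=O)oc2cc(OCC(=O)N/N=C/c3ccc(N(C)C)cc3)ccc12` gives 5540 nM as its result, and compound 2 `Cc1ccc(/C=N/NC(=O)COc2ccc3c(C)cc(=O)oc3c2)o1` gives 3190 nM on the same read-out. Within the data shown here, these are the only two measured numbers so far. They lie within the usual scatter of each other, so compound 2 cannot be ranked apart from compound 1.

Compound 3 `Cc1cc(=O)oc2cc(OCC(=O)NN3C(=O)C=CC3=O)ccc12` keeps the shared core and differs from compound 2 at one end of the molecule. The change is a group of 7 heavy atoms (4 carbon, 1 nitrogen, 2 oxygen; one five-membered non-aromatic ring with 1 hetero atom) in place of a group of 8 heavy atoms (6 carbon, 1 nitrogen, 1 oxygen; one five-membered aromatic ring with 1 hetero atom), on an amide-type nitrogen and it makes the ring at that end non-aromatic.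

Among the measured compounds shown here, the only measured step is a 1.7-fold lower number from compound 1 to compound 2 (0.24 log units; within the scatter) and it swapped 4-(dimethylamino)phenyl for 5-methylfuran-2-yl on a carbon with a double bond to nitrogen. For the measured compounds named here, that is a different kind of change, so it offers only a weak guide, and no measured compound carries the entering group. With no firm reason to expect a direction, the estimated result is a 1.1-fold lower number from compound 2 to compound 3 (0.03 log units; within the scatter) and so no shift beyond the scatter is expected. For compound 3 the estimated value is 3000 nM with an expected range from 800 nM to 11000 nM in this assay as a deliberately wide span.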

Compound 3, half-maximal inhibitory concentration: 2110 nM
Beside the measured number, compound 3's estimate is 1.4-fold (0.15 log units) above it; the measured number falls inside the stated range.
By their numbers in this assay, from the lowest: compounds 3, 2 and 1 (each within the scatter of the next, the first and the last beyond it).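

The step, a 1.5-fold lower number from compound 2 to compound 3 (0.18 log units; within the scatter), shows that in this assay the end group on the amide-type nitrogen can go from one with a five-membered aromatic ring to one with a five-membered non-aromatic ring without a shift that can be told from the scatter. The earlier step changed only which aromatic ring sat on a carbon with a double bond to nitrogen, so it could not show that the result holds when that carbon, its double bond to nitrogen and the aromatic ring all leave together. No measurement here bears on why the number stays in the same range, so this remains an observation about these compounds only.

This is a single step with one entering group, so it gives no trend for the amide-type nitrogen as a position and cannot say which part of the entering ring matters. As far as these compounds go, how this assay would respond to a very different end group there, such as a simple amine, a carboxylic acid or a longer alkyl chain, stays open.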